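Ketone aryl group variation across compounds 1 to 3

The source may report more compounds than this note shows. Statements on the series, on what has been measured and on what is new or still open speak of the compounds shown alone.

Compound 1 `COc1cc(-c2nnc3n2NC(c2ccco2)C(C(=O)c2ccccc2F)S3)cc(OC)c1OC` and compound 2 `COc1cc(-c2nnc3n2NC(c2ccco2)C(C(=O)c2ccc(Br)cc2)S3)cc(OC)c1OC` share one core and differ only in the aryl group on a carbonyl carbon. In a functional assay on PC-3 cells (Homo sapiens) for cytotoxicity, read by MTT assay, with a stated time of 48 h (on this read-out higher numbers stand for weaker inhibition and lower numbers for stronger inhibition), compound 1 gives only > 100000 nM, which is a limit of the assay and not a number. In this assay compound 2 gives 36400 nM, the only number shown in the series so far. For the measured compounds named here, the one other value, that of compound 1, is the limit of > 100000 nM in this assay, at which 1 of the 2 values shown sits. The measured step is an at least 2.7-fold lower number from compound 1 to compound 2 (0.43 log units; beyond the scatter). Compound 3 `COc1cc(-c2nnc3n2NC(c2ccco2)C(C(=O)c2cccs2)S3)cc(OC)c1OC` carries the next change: thiophen-2-yl in place of 4-bromophenyl on a carbonyl carbon. Going by the values given here, only the step from compound 1 to compound 2 bears on it, as the sole change made at that carbonyl carbon, and it was at least modest; thiophen-2-yl itself has no measured counterpart here. The expected step is a 1.2-fold higher number from compound 2 to compound 3 (0.09 log units; within the scatter), within the scatter or slightly towards a higher number in this assay. Compound 3 is therefore estimated at 45000 nM, with a range from 15000 nM to 100000 nM.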

Compound 3, half-maximal inhibitory concentration: 46200 nM
For compound 3 the middle estimate is 1.0-fold (0.01 log units) below the measured one, within the range that was stated.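

In this assay the exchange gives a 1.3-fold higher number from compound 2 to compound 3 (0.10 log units; within the scatter), so at this carbonyl carbon thiophen-2-yl and 4-bromophenyl cannot be told apart. Against 2-fluorophenyl the same group gives an at least 2.1-fold lower number from compound 1 to compound 3 (0.33 log units; beyond the scatter), so the separation from compound 1 no longer rests on 4-bromophenyl alone. Compound 1 still carries a limit of the assay and not a number: the limit of > 100000 nM in this assay, at which 1 of the 3 values shown sits.

Going by these compounds, only aromatic rings on the carbonyl carbon are covered, so it remains open how unsubstituted phenyl, a saturated cyclohexyl ring or an amine such as morpholine would read at this place. On these data alone, it also remains open whether any group here can bring the number in this assay well below those of compound 2 and compound 3.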